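The source may report more compounds than this note shows. Statements on the series, on what has been measured and on what is new or still open speak of the compounds shown alone.

Measured so far in a functional assay on MGC-803 cells (Homo sapiens) for inhibition, read by MTT assay, with a stated time of 48 h; a lower number here means a stronger inhibitor, a higher number a weaker inhibitor:
- compound 1 `C/C=C/C(=O)N(Cc1ccc(OC)c([N+](=O)[O-])c1)c1cc(OC)c(OC)c(OC)c1`: 590 nM
- compound 2 `COc1ccc(CNc2cc(OC)c(OC)c(OC)c2)cc1[N+](=O)[O-]`: 19400 nM
- compound 3 `COc1ccc(N(Cc2cc(OC)c(OC)c(OC)c2)C(=O)CN=[N+]=[N-])cc1O`: 22400 nM

In this assay, compound 2 at 19400 nM and compound 3 at 22400 nM lie within the scatter of each other. Going by the values given here, compound 2 is a much weaker inhibitor than compound 1, and that gap is the one measured step here: a 33-fold higher number from compound 1 to compound 2 (1.52 log units; beyond the scatter). This step is large, but it is hydrogen in place of (prop-1-en-1-yl)carbonyl on a nitrogen on an aromatic ring.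

The next compound, compound 4 `COc1ccc(CNc2cc(OC)c(OC)c(OC)c2)cc1C`, changes a different place. It carries methyl in place of nitro on an aromatic carbon, ortho to a methoxy group and meta to a large group. Among the compounds with values here, no measured step touches that carbon, so the large step shows only that this series can move strongly in this assay. It gives neither a size nor a direction for the new change.

The default expectation is therefore no step beyond the scatter, with real uncertainty either way. The expected step is a 1.3-fold lower number from compound 2 to compound 4 (0.11 log units; within the scatter). For compound 4 the estimated value is 15000 nM, with an expected range from 4000 nM to 50000 nM.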

Compound 4, half-maximal inhibitory concentration: 56800 nM
Compound 4: the middle estimate sits 3.8-fold (0.58 log units) below what was measured, and the stated range ends below it.
By their numbers in this assay, from the lowest: compound 1; then compounds 2 and 3 (each within the scatter of the next); then compound 4.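

In this assay, going by these compounds alone, the swap of nitro for methyl gives a 2.9-fold higher number from compound 2 to compound 4 (0.47 log units; beyond the scatter) as the first measured change on this aromatic carbon, ortho to a methoxy group. The step is modest but beyond the scatter, so this position is not indifferent to its group: nitro, with 3 heavy atoms and 2 hydrogen-bond acceptors, gives the stronger inhibitor here, and methyl, with 1 heavy atom and 0 hydrogen-bond acceptors, gives the weaker one. Nothing measured here explains this difference, so the result records its size and direction but not its cause.

This is a single pair, so it cannot show how other groups on this carbon would rank, such as a nitrile, an amine, a chlorine atom or plain hydrogen. It also leaves open whether the swap would move the number in the same direction and by a similar amount with the (prop-1-en-1-yl)carbonyl group on the nitrogen, the feature that sets compound 1 apart from compound 2.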